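Azetidin-3-yl in place of 1-methylpiperidin-3-yl on compound 1

The source may report more compounds than this note shows. Statements on the series, on what has been measured and on what is new or still open speak of the compounds shown alone.

- compound 1 `CN1CCCC(Cn2c(CN(C)C3CCCc4cccnc43)nc3ccccc32)C1`: 3000 nM
- compound 2 `CN1CCC[C@@H](Cn2c(CN(C)[C@@H]3CCCc4cccnc43)nc3ccccc32)C1`: 2800 nM

Both compounds were tested in an ADME assay on HOS cells (Homo sapiens) for cytotoxicity; on this read-out higher numbers stand for lower toxicity in this test and lower numbers for higher toxicity in this test. Among the compounds with values here, compound 1 stands level with compound 2, the only other compound measured so far, and the gap between them is a 1.1-fold lower number from compound 1 to compound 2 (0.03 log units; within the scatter). What separates the two is the fact that one of compounds 1 and 2 is drawn with a defined configuration and the other without, at the place where they differ, and no group changes between them.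

Compound 3 `CN(Cc1nc2ccccc2n1CC1CNC1)C1CCCc2cccnc21` has not yet been measured. It carries azetidin-3-yl in place of 1-methylpiperidin-3-yl, on a saturated chain carbon bound to an aromatic nitrogen: azetidin-3-yl in place of 1-methylpiperidin-3-yl on a saturated chain carbon bound to an aromatic nitrogen.

Within the data shown here, no measured step covers a swap of this kind, so the data give only a weak guide to its size. With only a 1.1-fold lower number from compound 1 to compound 2 (0.03 log units; within the scatter) to go on, the expectation stays anchored on compound 1 at 3000 nM, and no shift beyond the scatter is predicted, in either direction. The expected step is a 1.2-fold higher number from compound 1 to compound 3 (0.07 log units; within the scatter). As far as these compounds go, the range is kept wide since the ring change itself is untested. The estimate for compound 3 is 3500 nM, with an expected range from 1200 nM to 12000 nM.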

Compound 3, half-maximal cytotoxic concentration: 15000 nM
Estimate against measurement, compound 3: 4.3-fold (0.63 log units) below; the whole stated range lies below it.
By their numbers in this assay, from the lowest: compounds 2 and 1 (each within the scatter of the next); then compound 3.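

In this assay, within the data shown here, this position proves responsive for the first time: azetidin-3-yl in place of 1-methylpiperidin-3-yl, on a saturated chain carbon bound to an aromatic nitrogen, gives a 5.0-fold higher number from compound 1 to compound 3 (0.70 log units; beyond the scatter), whereas the only earlier step, a 1.1-fold lower number from compound 1 to compound 2 (0.03 log units; within the scatter), involved a difference in drawn configuration and no change of group. The new step therefore shows that replacing the group can move the number where a difference in drawn configuration did not, and it moves towards lower toxicity in this test. The change alters several features at once, with a six-membered ring giving way to a four-membered one, heavy atoms falling from 7 to 4 and hydrogen-bond donors rising from 0 to 1, and nothing on hand bears on which of these features accounts for the step.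

The compounds shown leave open whether ring size or the ring nitrogen's substitution carries the effect, a question that 1-methylazetidin-3-yl and piperidin-3-yl at this place would separate. They also leave open whether the number changes gradually with ring size, as pyrrolidin-3-yl would indicate, and whether the configuration at the azetidine-bearing compound's remaining stereocentre matters.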